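The source may report more compounds than this note shows. Statements on the series, on what has been measured and on what is new or still open speak of the compounds shown alone.

In an ADME assay on L02 cells (Homo sapiens) for cytotoxicity, read by MTT assay, with a stated time of 48 h (on this read-out higher numbers stand for weaker inhibition and lower numbers for stronger inhibition), compound 1 `CCN1CCN(C[C@H]2CN(c3ccc(-n4cc(-c5ccccn5)cn4)c(F)c3)C(=O)O2)CC1` gives 99 ug/mL.
Compound 2 `O=C1O[C@@H](CN2CCCCC2)CN1c1ccc(-n2cc(-c3ccccn3)cn2)c(F)c1` reaches only the limit of the assay, > 400 ug/mL.
Compound 3 `O=C1O[C@@H](CN2CCC(O)CC2)CN1c1ccc(-n2cc(-c3ccccn3)cn2)c(F)c1` also reaches only the limit of the assay, > 400 ug/mL.

Compound 3 therefore stands at the upper boundary of what this assay reports, a position it shares with compound 2, as the limit of > 400 ug/mL in this assay, at which 2 of the 3 values shown sit, records. Two measured steps lead to it: an at least 4.0-fold higher number from compound 1 to compound 3 (0.60 log units; beyond the scatter) and, in the same direction, an at least 4.0-fold higher number from compound 1 to compound 2 (0.60 log units; beyond the scatter). Between the two limit compounds the step that the two limits leave unreadable from compound 2 to compound 3 cannot be sized.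

Compound 4 `CONC(=O)[C@H]1CN(c2ccc(-n3cc(-c4ccccn4)cn3)c(F)c2)C(=O)O1` differs from compound 3 by methoxycarbamoyl in place of (4-hydroxypiperidin-1-yl)methyl on a saturated ring carbon. Going by the values given here, none of the measured steps touches this position of the shared core; all three concern the saturated chain carbon bound to a saturated ring carbon, and compound 4 has no such chain at all. The step to compound 4 is therefore expected to be readable only loosely, with an at least 1.3-fold lower number from compound 3 to compound 4 (0.12 log units; that floor lies within the scatter) as the estimated change. For compound 4 the expected value is 300 ug/mL, within a range from 80 ug/mL to 600 ug/mL.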

Compound 4, half-maximal inhibitory concentration: > 400 ug/mL
Compound 4 gave a limit, no number; the forecaster's own chance of this, stated with the estimate: 45%; at least 1.3-fold (0.12 log units) between middle value and limit.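

In this assay compound 4 gives > 400 ug/mL, which is a limit of the assay and not a number. Methoxycarbamoyl, which has no ring, in place of (4-ethylpiperazin-1-yl)methyl on the saturated ring carbon next to the ring oxygen gives an at least 4.0-fold higher number from compound 1 to compound 4 (0.60 log units; beyond the scatter), so this position is now seen to tolerate a change of the whole group and not only of the amine on the chain. The steps from compound 2 and from compound 3 to compound 4 cannot be read, and the series now gathers at one boundary: the limit of > 400 ug/mL in this assay, at which 3 of the 4 values shown sit.

As far as these compounds go, how the three limit compounds rank remains open, since none of them has a number. Also open, from the compounds shown here alone, is whether a morpholine on the chain, or a carboxylic acid at this ring carbon, would stay at that limit or fall towards compound 1.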